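A few compounds are considered here, and "the series" means these few. Any claim that something is new, unique, unknown or untested is made for them only; others in the source may bear on it.

Compound 1 `C=CCNc1ncnc2c1ncn2[C@H]1C[C@H](N=[N+]=[N-])[C@@H](CO)O1` gives 51100 nM in an ADME assay on PBMC cells (Homo sapiens) for cytotoxicity, with a stated time of 5 days; a lower number here means a stronger inhibitor, a higher number a weaker inhibitor.
Compound 2 `C=CCNc1nc(N)nc2c1ncn2[C@H]1C[C@H](N=[N+]=[N-])[C@@H](CO)O1` gives only a limit, > 100000 nM, in this assay.

Among the measured compounds shown here, compound 2 thus stands at the limit recorded in the limit of > 100000 nM in this assay, at which 1 of the 2 values shown sits; of the two measured compounds it is the one for which no number, only a limit, is known. For the measured compounds named here, the single measured step, an at least 1.9-fold higher number from compound 1 to compound 2 (0.29 log units; that floor lies within the scatter), concerns amino in place of hydrogen on an aromatic carbon and reaches only a floor that lies within the scatter. Compound 3 `C#CCNc1nc(N)nc2c1ncn2[C@H]1C[C@H](N=[N+]=[N-])[C@@H](CO)O1` differs from compound 2 by ethynyl in place of vinyl on a saturated chain carbon bound to a nitrogen on an aromatic ring. Going by the values given here, no measured step touches this change, so the measured compounds point in no direction for it. Compound 3 is therefore expected to give much the same reading as compound 2 in this assay, a step that the limit leaves unreadable from compound 2 to compound 3 that stays within the scatter, most likely again as a limit. The estimate for compound 3 is 150000 nM, with a range from 60000 nM to 400000 nM.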

Compound 3, half-maximal inhibitory concentration: > 100000 nM
Compound 3: no number, only a limit (the forecaster's own chance of this, stated with the estimate: 80%); the middle value lies beyond the limit too.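

Compound 2 and compound 3 both give only a limit, so no step can be read for ethynyl in place of vinyl between them: the limit of > 100000 nM in this assay, at which 2 of the 3 values shown sit.

The compounds shown leave open how far either lies beyond that limit, and whether allylamino to propargylamino changes the reading at all.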